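The compounds below may be only part of what the source reports. "The series", "measured", "known", "first", "only" and "open" are said of these compounds alone.

Compound 1 `CC(=O)N[C@H](C)[C@@H](O)[C@@H](C)[C@@H]1OC(=O)CC/C=C(C)\C=C\[C@]2(C)CCC=C[C@@H]2/C=C(C)/C=C/[C@H]1C` was tested in a functional assay on MCF7 cells (Homo sapiens) for antiproliferative activity, read by resazurin assay, with a stated time of 72 h (on this read-out higher numbers stand for weaker inhibition and lower numbers for stronger inhibition), and, in this assay, compound 1 returns only a limit, > 5000 nM. That reading is the one limit in the set, (the limit of > 5000 nM in this assay, at which 1 of the 2 values shown sits). Among the measured compounds shown here, compound 2 `CC(=O)N[C@H](C)[C@@H](O)[C@@H](C)[C@@H]1OC(=O)/C=C/C=C(C)\C=C\[C@]2(C)CCC=C[C@@H]2/C=C(C)/C=C/[C@H]1C` is the only member with an actual number: in this assay compound 2 gives 36.5 nM, and no measured pair differing in a single place is available to calibrate any step. Compound 3 `CC(=O)N[C@H](C)[C@@H](O)[C@@H](C)[C@@H]1OC(=O)/C=C/C=C(C)/C=C/[C@]2(C)CCC=C[C@@H]2/C=C(C)/C=C/[C@H]1C` has not yet been measured. It differs from compound 2 in this way: the two compounds have the same atoms and bonds and differ only in configuration as drawn: 1 of 12 stereo elements differ; a double bond is drawn Z in compound 2 and E in compound 3. Nothing measured here shows what such a change does in this assay. The author expects the step from compound 2 to compound 3 to be a 4.1-fold higher number from compound 2 to compound 3 (0.61 log units; beyond the scatter), a modest move toward weaker inhibition, with wide uncertainty. Compound 3 is accordingly estimated at 150 nM in this assay, within a range from 30 nM to 1500 nM.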

Compound 3, half-maximal inhibitory concentration: 376 nM
The estimate for compound 3 lay 2.5-fold (0.40 log units) below the measured number; measured number inside the range.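

Changing one double bond from Z to E, with no atom gained or lost, gives a 10-fold higher number from compound 2 to compound 3 (1.01 log units; beyond the scatter) in this assay. Among the compounds shown here, this is the first measured single-place step in the set, and it shows that the drawn geometry of this double bond alone can move the read-out well beyond the scatter, toward weaker inhibition. The step can be assigned to this one stereo element because nothing else separates the two compounds: the fact that compounds 2 and 3 differ only in the configuration as drawn

The compounds shown leave open whether the other double bonds of the shared core are as sensitive to a change of geometry as this one. They also leave open how the read-out would respond if the acetyl amide gave way to a free amine or a carboxylic acid.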